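Cyano in place of hydrogen on the aryl ring: compound 4

A few compounds are considered here, and "the series" means these few. Any claim that something is new, unique, unknown or untested is made for them only; others in the source may bear on it.

Compound 1 `C/C(=C\c1cc(-c2ccccc2)co1)C(N)=O`, compound 2 `C/C(=C\c1cc(-c2ccccc2)cs1)C(N)=O` and compound 3 `C/C(=C\c1cc(-c2ccccc2C)cs1)C(N)=O` make up the measured part of the series. In a functional assay on A549 cells (Homo sapiens) for cytotoxicity, read by CCK-8 assay, with a stated time of 24 h (on this read-out higher numbers stand for weaker inhibition and lower numbers for stronger inhibition), compound 1 gives > 50000 nM, which is a limit of the assay and not a number. In this assay compound 2 gives > 50000 nM, again a limit. In this assay compound 3 gives > 50000 nM, also a limit. The step that the two limits leave unreadable from compound 2 to compound 3, methyl in place of hydrogen on an aromatic carbon, is therefore unreadable, since all values shown sit at the limit of > 50000 nM in this assay, at which 3 of the 3 values shown sit. Compound 2 thus stands only at a limit, with no number of its own.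

Compound 4 `C/C(=C\c1cc(-c2ccc(C#N)cc2)cs1)C(N)=O` differs from compound 2 by cyano in place of hydrogen on an aromatic carbon. Among the compounds with values here, no measured step bears on this change in a readable way, and no value departs from the limit. Compound 4 is expected to give 80000 nM, with a range from 20000 nM to 300000 nM. The step that the limit leaves unreadable from compound 2 to compound 4 is expected to be none beyond the scatter, most likely reported as a limit again.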

Compound 4, half-maximal inhibitory concentration: > 50000 nM
Compound 4: no number, only a limit; the forecaster's own chance of this, stated with the estimate: 85%; the middle value is on the limit's open side.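

No step can be read from compound 2 to compound 4, since both stand only at a limit of the assay: the limit of > 50000 nM in this assay, at which 4 of the 4 values shown sit. As far as these compounds go, compound 1, compound 2, compound 3 and compound 4 have no number of their own, so whether any change on the shared core shifts the read-out stays open.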